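Lengthening the Amide Chain of a Threonine Amide

The source may hold more compounds than are shown below. What is called first, only, known or untested is meant among the compounds shown, and "the series" means these compounds.

Compound 1, `CCCCCCCCNC(=O)[C@@H](NC(=O)c1ccccc1)[C@@H](C)O`, is one of three close relatives tested in a functional assay on A-431 cells (Homo sapiens) for cytotoxicity, read by MTT assay, with a stated time of 48 h; on this read-out lower numbers stand for stronger inhibition and higher numbers for weaker inhibition. In this assay compound 1 gives 61300 nM, the second highest of the three numbers. Compound 2, `CCCCCCCCNC(=O)[C@@H](NC(=O)c1ccco1)[C@@H](C)O`, gives 64500 nM, and compound 3, `CCCCCCCCNC(=O)[C@@H](NC(=O)c1cc2ccccc2o1)[C@@H](C)O`, gives 52700 nM. The steps among them are small: a 1.1-fold higher number from compound 1 to compound 2 (0.02 log units; within the scatter), a 1.2-fold lower number from compound 1 to compound 3 (0.07 log units; within the scatter) and a 1.2-fold lower number from compound 2 to compound 3 (0.09 log units; within the scatter), each within the scatter, so the three cannot be ranked against one another.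

Compound 4, `CCCCCCCCCCCCCCCCCCNC(=O)[C@@H](NC(=O)c1ccccc1)[C@@H](C)O`, differs from compound 1 in one place: decyl in place of hydrogen on a saturated chain carbon, eight bonds along the chain from an amide-type nitrogen. The three measured steps all swap the aromatic group on the carbonyl carbon and leave the chain untouched, so none of them bears on this change. Nothing in the data shows what a longer chain does here. The expected step is therefore a 1.2-fold lower number from compound 1 to compound 4 (0.09 log units; within the scatter), with no direction beyond the scatter predicted and a deliberately wide range. Compound 4 is estimated at 50000 nM, between 15000 nM and 150000 nM.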

Compound 4, half-maximal inhibitory concentration: 113000 nM
Compound 4: middle estimate off by 2.3-fold (0.35 log units), on the low side; the measured number falls inside the stated range.
By their numbers in this assay, from the lowest: compounds 3, 1, 2 and 4 (each within the scatter of the next, the first and the last beyond it).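

Among these compounds, compound 4 gives the first look at the chain rather than the aromatic group on the carbonyl carbon. In this assay, putting decyl in place of hydrogen at this position gives a 1.8-fold higher number from compound 1 to compound 4 (0.27 log units; within the scatter), so this large addition produces no difference that can be told apart from ordinary repeat-to-repeat variation. No supporting measurement is available to explain this result.

One pair of compounds cannot show whether chain length matters in general, and a chain of another length might behave differently, as might an amine or a carboxylic acid in place of decyl. Going by these compounds, it also remains open whether furan-2-yl or 1-benzofuran-2-yl in place of phenyl on the carbonyl carbon would give similar numbers when paired with the longer chain.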